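A few compounds are considered here, and "the series" means these few. Any claim that something is new, unique, unknown or untested is made for them only; others in the source may bear on it.

Measured so far:
- compound 1, `COc1cc2c(cc1N1C[C@@H](C)N[C@@H](C)C1)N(C(=O)c1ccc(-c3cccc(C)n3)c3ccccc13)CC2`: 50.1 nM
- compound 2, `COc1cc2c(cc1N1CCN(C)CC1)N(C(=O)Nc1cccc(Cl)c1Cl)CC2`: 3.98 nM

In an assay on isolated protein for binding affinity to 5-hydroxytryptamine receptor 1B (Homo sapiens) (a higher number here means a weaker inhibitor, a lower number a stronger inhibitor), compound 2 gives the lower of the two numbers, well beyond the scatter from compound 1, which gives 50.1 nM. Compound 3, `COc1cc2c(cc1N1C[C@@H](C)N(C)[C@@H](C)C1)N(C(=O)Nc1cccc(Cl)c1Cl)CC2`, has not yet been measured. It differs from compound 2 in one place: 3,4,5-trimethylpiperazin-1-yl in place of 4-methylpiperazin-1-yl on an aromatic carbon. For the measured compounds named here, no measured pair shows this particular change, so its effect is open. The expectation for this assay is a step of modest size, possibly none beyond the scatter, leaning toward a slightly higher number, which is the step of a 1.5-fold higher number from compound 2 to compound 3 (0.18 log units; within the scatter). Compound 3 is therefore estimated at 6 nM, within a range of 1.5 nM to 25 nM.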

Compound 3, inhibition constant: 7.94 nM
For compound 3 the middle estimate is 1.3-fold (0.12 log units) below the measured one; measured number inside the range.
By their numbers in this assay, from the lowest: compounds 2 and 3 (each within the scatter of the next); then compound 1.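

In this assay, placing 3,4,5-trimethylpiperazin-1-yl in place of 4-methylpiperazin-1-yl on this aromatic carbon gives a 2.0-fold higher number from compound 2 to compound 3 (0.30 log units; within the scatter). This pair therefore shows that this position accepts the larger group, with its two defined stereocentres, without a change beyond the scatter. No measurement at hand explains this result.

From the compounds shown here alone, what remains open is whether a morpholin-4-yl or piperidin-1-yl group would also be accepted here. Going by these compounds, it is also open whether the trimethylpiperazine with its stereocentres reversed would behave in the same way.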